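The compounds below may be only part of what the source reports. "The series", "measured", "known", "first", "only" and "open" are said of these compounds alone.

The measured compounds:
compound 1 `CC#C[C@H]1CN(S(=O)(=O)c2ccc(N)nc2)CCN1c1ccc(C(=O)NC)cc1` — 4050 nM
compound 2 `CC#C[C@H]1CN(S(=O)(=O)c2ccc(N)nc2)CCN1c1ncc(C(C)(O)C(F)(F)F)s1` — > 12500 nM
compound 3 `CC#C[C@H]1CN(S(=O)(=O)c2ccc(N)nc2)CCN1c1ncc(C(O)(C(F)(F)F)C(F)(F)F)s1` — > 12500 nM

In an assay on cells (Hepatocyte) for inhibition of glucokinase regulatory protein (Mus musculus), with stated times of 20 min and 40 min (a higher number here means that more compound is needed for the effect, a lower number that less compound is needed), compound 1 gives 4050 nM. Compound 2 reaches only a limit of the assay, > 12500 nM. Compound 3 likewise sits at a limit, > 12500 nM. The step that the two limits leave unreadable from compound 2 to compound 3 therefore cannot be read. Within the data shown here, compound 1 stands as the only numbered value among the three, since the other two rest at the limit of > 12500 nM in this assay, at which 2 of the 3 values shown sit.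

Compound 4 `CC#C[C@H]1CN(S(=O)(=O)c2ccc(N)nc2)CCN1c1ccc(S(N)(=O)=O)cc1` differs from compound 1 by sulfamoyl in place of methylcarbamoyl on an aromatic carbon. Among the measured compounds shown here, no measured step bears on this change: the one step recorded, between compound 2 and compound 3, concerns a different part of the shared core and is itself unreadable. With nothing to point in either direction, no shift beyond the scatter is expected from the change. Compound 4 is therefore estimated at 4000 nM, with a range from 1300 nM to 12500 nM. This estimate means a step of a 1.0-fold lower number from compound 1 to compound 4 (0.01 log units; within the scatter), expected to lie within the usual scatter.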

Compound 4, half-maximal effective concentration: 37 nM
The estimate for compound 4 lay 110-fold (2.03 log units) above the measured number; the measured number lies below the stated range.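

In this assay sulfamoyl in place of methylcarbamoyl on an aromatic carbon, para to a large group, gives a 110-fold lower number from compound 1 to compound 4 (2.04 log units; beyond the scatter) and makes this the only position among the compounds shown where a single change can be read in size. The two groups have the same number of heavy atoms, and neither carries a ring or a net charge, so a step of this size goes with a change in which atoms are present and not with a change in heavy-atom count. Nothing measured here accounts for the size of the step.

As far as these compounds go, how other groups would read at this position remains open, for instance a carboxylic acid, a methylsulfonyl group or a sulfamoyl bearing a methyl on its nitrogen. Also open, from the compounds shown here alone, is whether sulfamoyl would give a similar step on the aromatic ring that compound 2 and compound 3 carry.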